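The source may report more compounds than this note shows. Statements on the series, on what has been measured and on what is new or still open speak of the compounds shown alone.

In a functional assay on HT-29 cells (Homo sapiens) for antiproliferative activity, read by MTT assay, with a stated time of 48 h (a lower number here means a stronger inhibitor of growth, a higher number a weaker inhibitor of growth), compound 1 `COC(=O)N1N=C(c2ccc(OC)cc2)CC1c1cc(OC)c(OC)c(OC)c1` gives 2550 nM, the lowest of three numbers. Compound 2 `CCOC(=O)N1N=C(c2ccc(OC)cc2)CC1c1cc(OC)c(OC)c(OC)c1` gives 6730 nM, and compound 3 `CCCOC(=O)N1N=C(c2ccc(OC)cc2)CC1c1cc(OC)c(OC)c(OC)c1` gives 12700 nM. Lengthening the ester chain produced a 5.0-fold higher number from compound 1 to compound 3 (0.70 log units; beyond the scatter), and then a 1.9-fold higher number from compound 2 to compound 3 (0.28 log units; within the scatter). Compound 4 `COC(=O)N1N=C(c2ccc(O)cc2)CC1c1cc(OC)c(OC)c(OC)c1` changes elsewhere: hydrogen in place of methyl on an oxygen on an aromatic ring, turning 4-methoxyphenyl into 4-hydroxyphenyl. For the measured compounds named here, no measured step touches this group, so the measured steps offer only a rough guide to size. The closest guide is a 2.6-fold higher number from compound 1 to compound 2 (0.42 log units; beyond the scatter), which suggests a modest change, with a higher number somewhat more likely than a lower one, though the direction remains uncertain. The expected change is a 1.5-fold higher number from compound 1 to compound 4 (0.17 log units; within the scatter). For compound 4 the estimate is 3800 nM, with an expected range from 1000 nM to 14000 nM.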

Compound 4, concentration for 50% growth inhibition: 6770 nM
Compound 4: the middle estimate sits 1.8-fold (0.25 log units) below what was measured; the measured number falls inside the stated range.
By their numbers in this assay, from the lowest: compound 1; then compounds 2, 4 and 3 (each within the scatter of the next).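

In this assay, the group on the aromatic ring far from the ester also affects growth inhibition: hydroxy in place of methoxy gives a 2.7-fold higher number from compound 1 to compound 4 (0.42 log units; beyond the scatter) and is a modest loss. With this step, compound 1 keeps the lowest number of the four compounds, so removing this methyl gives no gain here. Nothing measured here explains the loss.

As far as these compounds go, whether ethoxy or an amine at this place would lower or raise the number stays open. So does whether the same swap would give a similar step on the ethyl or propyl esters.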